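Working notes on three aryl alcohols and a fourth

This account rests on a few compounds, and the source may have more. Where it says the series, first, only, none or still open, it means among the compounds named here.

Measured so far:
compound 1 `OC(CCn1nc2c(Br)c(Br)c(Br)c(Br)c2n1)c1ccc(F)cc1` — 0%
compound 2 `COc1cccc(C(O)CCn2nc3c(Br)c(Br)c(Br)c(Br)c3n2)c1` — 6%
compound 3 `OC(CCn1nc2c(Br)c(Br)c(Br)c(Br)c2n1)c1ccccc1` — 0%

In a functional assay on MCF7 cells (Homo sapiens) for antiproliferative activity, read by MTT assay, with a stated time of 48 h, tested at 100 uM (on this read-out lower numbers stand for a stronger effect and higher numbers for a weaker effect at the one concentration tested), compound 3 gives 0%, level with compound 1 and together with it the lowest of the three numbers; both no change at the digits printed from compound 1 to compound 3 (within the scatter) and a number 6 percentage points lower from compound 2 to compound 3 (within the scatter) lie within the scatter, so the three compounds are indistinguishable on this read-out.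

Compound 4 `OC(CCn1nc2c(Br)c(Br)c(Br)c(Br)c2n1)c1ccc(Br)cc1` differs from compound 3 by bromo in place of hydrogen on an aromatic carbon. Among the measured compounds shown here, the only measured step at the same position is no change at the digits printed from compound 1 to compound 3 (within the scatter), which was flat, and the larger swap a number 6 percentage points higher from compound 1 to compound 2 (within the scatter) was also within the scatter. For the measured compounds named here, no step so far moves the number, so no step beyond the scatter is expected here either: compound 4 is estimated at 2% (range 0% to 12%), an expected step of a number 2 percentage points higher from compound 3 to compound 4 (within the scatter).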

Compound 4, a percentage reported as activity, at one concentration (the size of the read-out at that concentration, not a potency): 0%
Compound 4: the middle estimate sits 2 percentage points above what was measured; the range from low to high includes it.
By their numbers in this assay, from the lowest: compounds 1, 3, 4 and 2 (each within the scatter of the next).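

In this assay, the bromo at this aromatic carbon, para to a large group, gives no change at the digits printed from compound 3 to compound 4 (within the scatter) and, set against fluoro at the same carbon, no change at the digits printed from compound 1 to compound 4 (within the scatter) so the flat read-out now extends from hydrogen and fluoro to bromo. Exchanging 3-methoxyphenyl for 4-bromophenyl gives a number 6 percentage points lower from compound 2 to compound 4 (within the scatter) and so separates neither ring pattern. No measurement on hand explains this flatness. Open, as far as these compounds go, is whether an amine or a carboxylic acid on this aromatic carbon, or a longer chain to the shared core, would move the number at all.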